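A few compounds are considered here, and "the series" means these few. Any claim that something is new, unique, unknown or untested is made for them only; others in the source may bear on it.

Measured set, a functional assay on DLD-1 cells (Homo sapiens) for antiproliferative activity, read by CellTiter-Glo, with a stated time of 72 h; on this read-out higher numbers stand for weaker inhibition and lower numbers for stronger inhibition:
Compound 1 `Cc1cc(C)c(S(=O)(=O)N2CCC(N3CCC(CCO)CC3)CC2)c(C)c1` gives 19 nM.
Compound 2 `CC1CCN(C2CCN(S(=O)(=O)c3cccnc3F)CC2)CC1` gives > 5000 nM, a limit of the assay (the limit of > 5000 nM in this assay, at which 1 of the 3 values shown sits).
Compound 3 `Cc1cc(C)c(S(=O)(=O)N2CCC(N3CCN(C)CC3)CC2)c(C)c1` gives 1100 nM.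

For the measured compounds named here, compound 3 stands with the highest of the two numbers in this assay; the single measured step ends at it: a 58-fold higher number from compound 1 to compound 3 (1.76 log units; beyond the scatter). Compound 4 `Cc1cc(C)c(S(=O)(=O)N2CCC(N3CC(C)CC(C)C3)CC2)c(C)c1` differs from compound 3 by 3,5-dimethylpiperidin-1-yl in place of 4-methylpiperazin-1-yl on a saturated ring carbon. Going by the values given here, only that one step bears on the change: it ran from a 4-(2-hydroxyethyl)piperidin-1-yl group to 4-methylpiperazin-1-yl, and compound 4 returns to a piperidin-1-yl group, though a 3,5-dimethylpiperidin-1-yl without the hydroxyethyl. A step back downward is therefore expected, but smaller than the measured one. Compound 4 is expected at 150 nM (range 30 nM to 800 nM), i.e. an expected 7.3-fold lower number from compound 3 to compound 4 (0.87 log units; beyond the scatter).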

Compound 4, half-maximal inhibitory concentration: 17 nM
Beside the measured number, compound 4's estimate is 8.8-fold (0.95 log units) above it; the whole stated range lies above it.
By their numbers in this assay, from the lowest: compounds 4 and 1 (each within the scatter of the next); then compound 3. At a limit, above all of these: compound 2.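

Putting 3,5-dimethylpiperidin-1-yl in place of 4-methylpiperazin-1-yl on this saturated ring carbon gives a 65-fold lower number from compound 3 to compound 4 (1.81 log units; beyond the scatter) and shows that a low number at this position does not depend on the 2-hydroxyethyl chain. The two piperidin-1-yl groups differ little, with a 1.1-fold lower number from compound 1 to compound 4 (0.05 log units; within the scatter) and no order between them. No measurement shown gives a cause for these steps.

Left open is how an unsubstituted piperidin-1-yl, a morpholin-4-yl or a 4-aminopiperidin-1-yl group would read at this position.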